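The source may report more compounds than this note shows. Statements on the series, on what has been measured and on what is new or still open speak of the compounds shown alone.

Measured compounds in a functional assay on HeLa cells (Homo sapiens) for inhibition, read by CCK-8 assay, with a stated time of 72 h, tested at 8 uM; a lower number here means less inhibition of growth, a higher number more inhibition of growth at the concentration tested:

compound 1 `COc1ccc(SCc2ccc(/C=C/C(=O)Nc3ccccc3N)cc2)cc1OC` gives 21.9%
compound 2 `Nc1ccccc1NC(=O)/C=C/c1ccc(CSc2cccc(F)c2)cc1` gives 18.6%
compound 3 `Nc1ccccc1NC(=O)/C=C/c1ccc(CSCCc2ccccc2)cc1` gives 3.57%

Compound 3 holds the lowest of the three numbers. Its nearest neighbour is compound 2, with the step of a number 15 percentage points lower from compound 2 to compound 3 (beyond the scatter), and the widest gap is to compound 1, with the step of a number 18.3 percentage points lower from compound 1 to compound 3 (beyond the scatter). The two compounds with an aromatic ring directly on the sulfur, compound 1 and compound 2, sit close together, as the step of a number 3.3 percentage points lower from compound 1 to compound 2 (within the scatter) shows.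

Compound 4 `CCc1ccc(SCc2ccc(/C=C/C(=O)Nc3ccccc3N)cc2)cc1` is not yet measured. It differs from compound 3 in one place: 4-ethylphenyl in place of phenethyl on a sulfur. This change returns an aromatic ring to the sulfur, which is the same kind of arrangement found in compound 1 and compound 2. Both steps that removed such a ring in favour of phenethyl, a number 18.3 percentage points lower from compound 1 to compound 3 (beyond the scatter) and a number 15 percentage points lower from compound 2 to compound 3 (beyond the scatter), were modest and downward, so the reverse move is expected to be of similar size and upward. The estimated step is a number 16.4 percentage points higher from compound 3 to compound 4 (beyond the scatter). Compound 4 is therefore expected to reach about 20% in this assay, with a range from 8% to 32%.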

Compound 4, percent growth inhibition at one concentration: 20.9%
Estimate against measurement, compound 4: 0.9 percentage points below; the measured number falls inside the stated range.
By their numbers in this assay, from the lowest: compound 3; then compounds 2, 4 and 1 (each within the scatter of the next).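

Phenethyl and 4-ethylphenyl have the same atoms and the same counts, so the change on the sulfur in this assay (a number 17.3 percentage points higher from compound 3 to compound 4 (beyond the scatter)) compares two arrangements of one set of atoms, which the earlier steps, all of which also changed the atoms, could not do. The 4-ethylphenyl compound cannot be told apart from the compounds carrying 3-fluorophenyl (a number 2.3 percentage points higher from compound 2 to compound 4 (within the scatter)) or 3,4-dimethoxyphenyl (a number 1 percentage points lower from compound 1 to compound 4 (within the scatter)), so these three groups on the sulfur fall together and compound 3 alone stands apart. No measurement at hand explains this difference.

Still open, going by these compounds, is whether benzyl on the sulfur would fall with phenethyl or with the three aromatic groups. Also open, on these data alone, is how an amine or a carboxylic acid on the aromatic ring, or a longer chain in place of ethyl, would read at this single concentration.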